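Swapping Pyridin-3-yl for Phenyl on a Shared Core

This account rests on a few compounds, and the source may have more. Where it says the series, first, only, none or still open, it means among the compounds named here.

Compound 1 `CCc1cc2c(N/N=C\c3cccs3)ncnc2s1`: 0.566 ug/mL
Compound 2 `CCc1cc2c(N/N=C\C3CC3)ncnc2s1`: "not determined" (no result reported)
Compound 3 `CC(C)c1cc2c(N/N=C\c3cccnc3)ncnc2s1`: 0.889 ug/mL

In a functional assay on PC-6 cells (Homo sapiens) for antiproliferative activity (a lower number here means a stronger inhibitor, a higher number a weaker inhibitor), compound 3 gives 0.889 ug/mL, the higher of the two numbers recorded, while compound 1 gives 0.566 ug/mL; the gap between them lies within the scatter, so the two cannot be ranked. Compound 2 has no result in this assay. Compound 4 `CC(C)c1cc2c(N/N=C\c3ccccc3)ncnc2s1` is not yet measured. It differs from compound 3 in one place: phenyl in place of pyridin-3-yl on a carbon with a double bond to nitrogen. Within the data shown here, no pair of measured compounds shows this same change, so there is no measured step to lean on. The change is expected to shift the number in this assay little, if at all, beyond the scatter, in either direction. Compound 4 is therefore estimated at 0.9 ug/mL, with a range from 0.3 ug/mL to 2.7 ug/mL. The expected step is a 1.0-fold higher number from compound 3 to compound 4 (0.01 log units; within the scatter).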

Compound 4, half-maximal inhibitory concentration: 0.651 ug/mL
For compound 4 the middle estimate is 1.4-fold (0.14 log units) above the measured one, and the stated range covers the measured number.
By their numbers in this assay, from the lowest: compounds 1, 4 and 3 (each within the scatter of the next).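

In this assay, among these compounds, the change from pyridin-3-yl to phenyl gives a 1.4-fold lower number from compound 3 to compound 4 (0.14 log units; within the scatter) and so is the first direct comparison at this position. On a carbon with a double bond to nitrogen, the two rings cannot be told apart, so in this pair the ring nitrogen and its hydrogen-bond acceptor can go without a shift beyond the scatter. No measurement at hand explains this result.

This is a single pair on one core, so it may not hold on others. On these data alone, whether a phenyl carrying an amine or a carboxylic acid would shift the number beyond the scatter stays open.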